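Swapping the oxygen substituent: compound 2 to compound 3

The compounds below may be only part of what the source reports. "The series", "measured", "known", "first", "only" and "open" are said of these compounds alone.

compound 1 (`CC(C)=CC[C@@H](OC(=O)CCO)C1=CC(=O)c2c(O)ccc(O)c2C1=O`): 67600 nM
compound 2 (`CC(C)=CC[C@@H](OCC(C)O)C1=CC(=O)c2c(O)ccc(O)c2C1=O`): 24700 nM

In a functional assay on HeLa cells (Homo sapiens) for cytotoxicity, read by MTT assay (a lower number here means a stronger inhibitor, a higher number a weaker inhibitor), compound 2 holds the lower of the two numbers. Compound 3 (`CC(C)=CC[C@@H](OC(=O)CC(C)(O)C(C)C)C1=CC(=O)c2c(O)ccc(O)c2C1=O`) changes one group ((2-hydroxy-2,3-dimethylbutyl)carbonyl in place of 2-hydroxypropyl on an oxygen on a saturated carbon): (2-hydroxy-2,3-dimethylbutyl)carbonyl in place of 2-hydroxypropyl on an oxygen on a saturated carbon. Within the data shown here, one measured step bears on this (a 2.7-fold lower number from compound 1 to compound 2 (0.44 log units; beyond the scatter)), and it is modest. Compound 3 has a carbonyl on that oxygen, as does compound 1 (67600 nM). A modest rise is therefore expected for compound 3 (a 1.6-fold higher number from compound 2 to compound 3 (0.21 log units; within the scatter)). Compound 3 is estimated at 40000 nM with 15000 nM to 100000 nM as its range.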

Compound 3, half-maximal inhibitory concentration: 27700 nM
The estimate for compound 3 lay 1.4-fold (0.16 log units) above the measured number, and the stated range covers the measured number.
By their numbers in this assay, from the lowest: compounds 2 and 3 (each within the scatter of the next); then compound 1.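

In this assay, a carbonyl on this oxygen does not by itself keep the number high: the step (a 1.1-fold higher number from compound 2 to compound 3 (0.05 log units; within the scatter)) stays within the scatter despite the larger group. Between the two compounds carrying that carbonyl, 1-hydroxy-1,2-dimethylpropyl in place of hydroxymethyl gives the step (a 2.4-fold lower number from compound 1 to compound 3 (0.39 log units; beyond the scatter)), so the chain beyond the carbonyl also counts at this position. Nothing available explains either step. Still open, going by these compounds, is how an amine or a carboxylic acid in place of the hydroxyl on this chain would read, and whether the hydroxyl is needed at all.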